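The source may report more compounds than this note shows. Statements on the series, on what has been measured and on what is new or still open speak of the compounds shown alone.

Of the compounds shown here, three built on one shared core have been measured in a functional assay on the whole organism for inhibition of sodium-dependent dopamine transporter (Mus musculus) (on this read-out lower numbers stand for an effect already at smaller amounts and higher numbers for an effect only at larger amounts of compound), and a fourth awaits measurement. Compound 1 `CCCNC(=O)Nc1cccc2c1CN(C)CC2c1ccccc1` carries a propylamino group on the carbonyl carbon. In this assay compound 1 reaches only a limit of > 120 mg/kg, which is a limit of the measurement and not a number, as the line the limit of > 120 mg/kg in this assay, at which 1 of the 3 values shown sits, records. Compound 2 `CCCCNC(=O)Nc1cccc2c1CN(C)CC2c1ccccc1` differs from compound 1 by methyl in place of hydrogen on a saturated chain carbon, three bonds along the chain from an amide-type nitrogen. In this assay compound 2 gives 69 mg/kg, and the step of an at least 1.7-fold lower number from compound 1 to compound 2 (0.24 log units; that floor lies within the scatter) cannot be read more closely than that. Compound 3 `CCNCCC(=O)Nc1cccc2c1CN(C)CC2c1ccccc1` has a different core, the difference being (2-(ethylamino)ethyl in place of propylamino on a carbonyl carbon). In this assay compound 3 gives 190 mg/kg, and the step of a 2.8-fold higher number from compound 2 to compound 3 (0.44 log units; beyond the scatter) is a modest one in the direction of a larger dose, while the step that the limit leaves unreadable from compound 1 to compound 3 stays unreadable. Compound 4 `CC(C)NCCC(=O)Nc1cccc2c1CN(C)CC2c1ccccc1`, not yet measured, differs from compound 3 by methyl in place of hydrogen on a saturated chain carbon bound to an amine nitrogen and a saturated chain carbon. Within the data shown here, this is the same kind of change as the one from compound 1 to compound 2, but the place differs: there the methyl enters on a saturated chain carbon three bonds along the chain from an amide-type nitrogen, here on a saturated chain carbon bound to an amine nitrogen and a saturated chain carbon. Because the earlier step of an at least 1.7-fold lower number from compound 1 to compound 2 (0.24 log units; that floor lies within the scatter) had a floor within the scatter, the step from compound 3 to compound 4 is expected to be small, a 1.3-fold lower number from compound 3 to compound 4 (0.10 log units; within the scatter). For compound 4 in this assay a value of about 150 mg/kg is estimated, expected to lie between 70 mg/kg and 320 mg/kg.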

Compound 4, dose for half-maximal effect: about 200 mg/kg
Estimate against measurement, compound 4: 1.3-fold (0.12 log units) below, and the stated range covers the measured number.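

In this assay, exchanging ethylamino for isopropylamino gives a 1.1-fold higher number from compound 3 to compound 4 (0.02 log units; within the scatter), so the added methyl produces no readable change on this core. Replacing the butylamino group with 2-(isopropylamino)ethyl on the carbonyl carbon gives a 2.9-fold higher number from compound 2 to compound 4 (0.46 log units; beyond the scatter). The steps from compound 1 to compound 3 and to compound 4 cannot be read.

Set side by side, the methyl change reads as follows on the two cores: the same change on two cores in this assay, an at least 1.7-fold lower number (0.24 log units; that floor lies within the scatter) from compound 1 to compound 2 and a 1.1-fold higher number (0.02 log units; within the scatter) from compound 3 to compound 4; the limit leaves it open whether they differ. Compound 1 has only a limit, not a number: the limit of > 120 mg/kg in this assay, at which 1 of the 4 values shown sits. The series therefore shows that the methyl has no readable effect in the 2-(ethylamino)ethyl setting, but not whether the change carries from one core to another with the same size or with a different one.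

The compounds shown leave open whether a longer chain on the amine nitrogen, such as butyl, or a ring there, such as cyclopropyl, would shift the dose away from that of the ethylamino and isopropylamino compounds. They also leave open how a tertiary amine or a carboxylic acid at the end of the side chain would read in this assay.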